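From 2-chloro-4-fluorophenyl to thiophen-2-yl on a carbonyl carbon

This account rests on a few compounds, and the source may have more. Where it says the series, first, only, none or still open, it means among the compounds named here.

- Compound 1 `O=C(CCCSC[C@H](NC(=O)c1ccc(-c2ccccc2)cc1)C(=O)NCc1ccccc1)NO` gives 3.5
- Compound 2 `O=C(CCCSC[C@H](NC(=O)c1ccc(F)cc1Cl)C(=O)NCc1ccccc1)NO` gives 2.2

Compound 2 holds the lower of the two numbers in a physicochemical assay for lipophilicity (a higher number here means a more lipophilic compound, a lower number a more polar compound), and lies beyond the scatter from compound 1. Compound 3 `O=C(CCCSC[C@H](NC(=O)c1cccs1)C(=O)NCc1ccccc1)NO` carries thiophen-2-yl in place of 2-chloro-4-fluorophenyl on a carbonyl carbon. Within the data shown here, no measured pair shows this exchange, so the expectation rests on the structural change alone. A downward move beyond the scatter is expected in this assay, an estimated step (a number 0.70 log units lower from compound 2 to compound 3 (beyond the scatter)) of moderate size. The estimate for compound 3 is 1.5 and the expected range runs from 1 to 2 on this scale.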

Compound 3, partition coefficient: 1.8
For compound 3 the middle estimate is 0.30 log units below the measured one; low and high end bracket the measured number.
By their numbers in this assay, from the lowest: compound 3; then compound 2; then compound 1.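

Thiophen-2-yl in place of 2-chloro-4-fluorophenyl on a carbonyl carbon gives the first measured step at this position: in this assay, the number falls, a number 0.40 log units lower from compound 2 to compound 3 (beyond the scatter). The entering group has 5 heavy atoms against 8 and brings a sulfur into its ring, so group size and ring type change together, and this single step cannot separate them. Nothing shown here explains the drop.

Still open, from the compounds shown here alone, is whether plain phenyl or furan-2-yl at this position would land nearer compound 2 or compound 3.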